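This account rests on a few compounds, and the source may have more. Where it says the series, first, only, none or still open, it means among the compounds named here.

Compound 1 `O=C(NC(=S)Nc1ccc(F)cc1)c1cn(-c2ccccc2)nc1-c1ccc(F)cc1` is tested in a functional assay on NCI-H460 cells (Homo sapiens) for inhibition, read by CCK-8 assay, with a stated time of 48 h (on this read-out lower numbers stand for stronger inhibition and higher numbers for weaker inhibition), where compound 1 gives 3240 nM. Two close relatives are measured alongside it: compound 3 `O=C(NC(=S)Nc1ccc(Cl)cc1)c1cn(-c2ccccc2)nc1-c1ccc(F)cc1`, which gives 3090 nM, and compound 2 `COc1ccc(-c2nn(-c3ccccc3)cc2C(=O)NC(=S)Nc2ccc(Cl)cc2)cc1`, which gives 3010 nM. Of these three numbers compound 1 holds the highest, yet all three sit within the scatter of one another, so no order can be read from them. The unmeasured compound 4 `Cc1ccc(-c2nn(-c3ccccc3)cc2C(=O)NC(=S)Nc2ccc(F)cc2)cc1` differs from compound 1 in a single place: methyl in place of fluoro on an aromatic carbon. The step that bears most directly on this exchange is the one at the same aromatic carbon, which came to a 1.0-fold higher number from compound 2 to compound 3 (0.01 log units; within the scatter). The other measured step, on the other aromatic ring, a 1.0-fold lower number from compound 1 to compound 3 (0.02 log units; within the scatter), was equally flat. Nothing measured here indicates that swapping one small substituent on this ring moves this assay beyond the scatter, and compound 4 is expected to show a 1.0-fold lower number from compound 1 to compound 4 (0.01 log units; within the scatter). Compound 4 is therefore estimated at 3200 nM, with a range from 1600 nM to 6400 nM.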

Compound 4, half-maximal inhibitory concentration: 3980 nM
For compound 4 the middle estimate is 1.2-fold (0.09 log units) below the measured one; the measured number falls inside the stated range.
By their numbers in this assay, from the lowest: compounds 2, 3, 1 and 4 (each within the scatter of the next).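

In this assay, the exchange of 4-fluorophenyl for 4-methylphenyl came to a 1.2-fold higher number from compound 1 to compound 4 (0.09 log units; within the scatter). The earlier step at this aromatic carbon, between methoxy and fluoro, was read with chloro on the other aromatic ring, whereas this one is read with fluoro there, so the position stays flat in both settings and methyl joins methoxy and fluoro as groups that leave the number within the scatter. No measurement shown here offers any account of this flatness.

On these data alone, whether an amine, a carboxylic acid or a longer chain such as butyl at this position would carry the number beyond the scatter remains open. Also open, as far as these compounds go, is whether a change to the thiourea linker or to the phenyl group on the shared core would shift this assay more than these small substituents do.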